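The compounds below may be only part of what the source reports. "The series", "measured", "known", "first", "only" and "open" are said of these compounds alone.

Compound 3 `Cc1cccc(/C=N/NC(=O)CSc2nnnn2-c2cccc3ccccc23)c1` gives 269000 nM in an ADME assay on MT4 cells (Homo sapiens) for cytotoxicity, read by MTT assay (on this read-out lower numbers stand for higher toxicity in this test and higher numbers for lower toxicity in this test), the highest of the two numbers shown. Compound 1 `O=C(CSc1nnnn1-c1cccc2ccccc12)N/N=C/c1ccccc1Cl` gives 69700 nM. Compound 2 `O=C(CSc1nnnn1-c1cccc2ccccc12)N/N=C/c1ccc([N+](=O)[O-])cc1` reaches only the limit of the assay, >= 260000 nM. The two readable steps both came from compound 1: a 3.9-fold higher number from compound 1 to compound 3 (0.59 log units; beyond the scatter), and an at least 3.7-fold higher number from compound 1 to compound 2 (0.57 log units; beyond the scatter). The step from compound 2 to compound 3 cannot be read. Compound 4 `O=C(CSc1nnnn1-c1cccc2ccccc12)N/N=C/c1ccccc1O` differs from compound 3 in one place: 2-hydroxyphenyl in place of 3-methylphenyl on a carbon with a double bond to nitrogen. The measured steps bear on this change only loosely, since each swaps the aryl group on the same carbon and none moves the number more than modestly. The expected step is therefore small, a 1.5-fold lower number from compound 3 to compound 4 (0.17 log units; within the scatter). Compound 4 is expected at about 180000 nM, within 60000 nM to 300000 nM.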

Compound 4, half-maximal cytotoxic concentration: 4850 nM
Compound 4: middle estimate off by 37-fold (1.57 log units), on the high side, and the stated range ends above it.
By their numbers in this assay, from the lowest: compound 4; then compound 1; then compound 3.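

Changing the aryl group on a carbon with a double bond to nitrogen can move the number in this assay much further than the earlier modest steps suggested, with a 55-fold lower number from compound 3 to compound 4 (1.74 log units; beyond the scatter) and an at least 53-fold lower number from compound 2 to compound 4 (1.72 log units; beyond the scatter). Hydroxy in place of chloro on an aromatic carbon still gives a 14-fold lower number from compound 1 to compound 4 (1.16 log units; beyond the scatter), so compound 4 stands apart from all three earlier compounds. Compound 2 enters this comparison only as a limit: the limit of >= 260000 nM in this assay, at which 1 of the 4 values shown sits.

As far as these compounds go, what stays open is whether the drop is specific to the hydroxy group. An amine or a methoxy group in its place would bear on that, and the compounds shown cannot tell.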